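The source may report more compounds than this note shows. Statements on the series, on what has been measured and on what is new or still open speak of the compounds shown alone.

Measured so far:
- compound 1, `Cc1cc(Nc2cc(-c3ccccc3)[nH]n2)n2nc(SCc3c(Cl)cccc3Cl)nc2n1`, with 5280 nM in a functional assay on MGC-803 cells (Homo sapiens) for inhibition, read by MTT assay, with a stated time of 72 h; a lower number here means a stronger inhibitor, a higher number a weaker inhibitor
- compound 2, `Cc1cc(Nc2cc(-c3ccccc3)[nH]n2)n2nc(SCc3ccc(Br)cc3)nc2n1`, with 1110 nM in this assay
- compound 3, `Cc1cc(Nc2ccn(Cc3ccc(F)cc3)n2)n2nc(SCc3ccc(Br)cc3)nc2n1`, with 3070 nM in this assay

Among these three, compound 2 has the lowest number in this assay; compound 3 sits nearest, and compound 1 furthest, with a 4.8-fold lower number from compound 1 to compound 2 (0.68 log units; beyond the scatter) being the only step between measured compounds that differ in one place.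

Compound 4, `COc1ccc(CSc2nc3nc(C)cc(Nc4cc(-c5ccccc5)[nH]n4)n3n2)cc1`, is compound 2 with one change: methoxy in place of bromo on an aromatic carbon. Going by the values given here, no measured pair probes a methoxy against a bromo on that ring. Among the compounds with values here, the one measured step, a 4.8-fold lower number from compound 1 to compound 2 (0.68 log units; beyond the scatter), concerns a different exchange on the same benzyl ring and shows that substitution of that ring can shift the number modestly, but it gives no direction for methoxy. The expectation is therefore a step no larger than that one, most likely within the scatter, so compound 4 is estimated at 1600 nM, with a range from 600 nM to 4500 nM, which corresponds to an expected 1.4-fold higher number from compound 2 to compound 4 (0.16 log units; within the scatter).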

Compound 4, half-maximal inhibitory concentration: 3170 nM
Compound 4: the middle estimate sits 2.0-fold (0.30 log units) below what was measured; measured number inside the range.
By their numbers in this assay, from the lowest: compound 2; then compounds 3, 4 and 1 (each within the scatter of the next).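

Going by these compounds alone, the exchange of bromo for methoxy on this aromatic carbon is the first direct test of the substituent at this place, and in this assay it gives a 2.9-fold higher number from compound 2 to compound 4 (0.46 log units; beyond the scatter), so the ring is sensitive to more than the change from the 2,6-dichlorophenyl group. Set against that, a 1.7-fold lower number from compound 1 to compound 4 (0.22 log units; within the scatter) leaves the 4-methoxyphenyl and 2,6-dichlorophenyl compounds indistinguishable, and among these three benzyl variants only the 4-bromophenyl group of compound 2 stands apart, with steps beyond the scatter to both others. Nothing available bears on the reason for this difference.

Going by these compounds, it remains open whether bromo is particular here or whether a chloro, a nitrile or an amine at the same carbon would read as compound 2 does. Also open, on these data alone, is whether the methoxy step would carry over to the core of compound 3.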